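A few compounds are considered here, and "the series" means these few. Any claim that something is new, unique, unknown or untested is made for them only; others in the source may bear on it.

Compound 2 `O=C(CNC(=O)c1ccc(C#Cc2ccccc2)cc1)NO` is one of two compounds whose solubility has been measured in a physicochemical assay for solubility; on this read-out higher numbers stand for higher solubility and lower numbers for lower solubility. Compound 1 `O=C(N[C@H](CO)C(=O)NO)c1ccc(C#Cc2ccccc2)cc1` gives 36000 nM, and compound 2 gives 21000 nM, so the two numbers sit within the scatter of each other, as the step of a 1.7-fold lower number from compound 1 to compound 2 (0.23 log units; within the scatter) shows. Compound 3 `CC(C)(NC(=O)c1ccc(C#Cc2ccccc2)cc1)C(=O)NO` has not yet been measured in this assay. It differs from compound 2 in one place: 1-(hydroxycarbamoyl)-1-methylethyl in place of (hydroxycarbamoyl)methyl on an amide-type nitrogen. For the measured compounds named here, only one measured step bears on this change, since it is the only one that also alters the saturated chain carbon bound to the amide-type nitrogen and the carbonyl carbon, and that step, a 1.7-fold lower number from compound 1 to compound 2 (0.23 log units; within the scatter), stayed within the scatter. On that footing the step from compound 2 to compound 3 in this assay is expected to be modest as well, with no direction claimed beyond the scatter. The expected step is a 1.2-fold lower number from compound 2 to compound 3 (0.07 log units; within the scatter). The solubility of compound 3 in this assay is therefore estimated at 18000 nM, within a range from 7000 nM to 45000 nM.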

Compound 3, solubility: 182000 nM
Compound 3: middle estimate off by 10-fold (1.00 log units), on the low side; measured number outside the range, above it.
By their numbers in this assay, from the lowest: compounds 2 and 1 (each within the scatter of the next); then compound 3.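

In this assay, for the compounds shown here, a change at the saturated chain carbon on the amide-type nitrogen now gives a step beyond the scatter, an 8.7-fold higher number from compound 2 to compound 3 (0.94 log units; beyond the scatter), whereas the only earlier change there, a 1.7-fold lower number from compound 1 to compound 2 (0.23 log units; within the scatter), stayed within it. The 1-(hydroxycarbamoyl)-1-methylethyl group also separates from the hydroxymethyl-bearing group of the same size in heavy atoms, a 5.1-fold higher number from compound 1 to compound 3 (0.70 log units; beyond the scatter), so the nature of the group on the amide-type nitrogen matters here and not only its heavy-atom count, and compound 3 gives the highest number of the three. No measurement offered here accounts for this higher number.

The compounds shown leave open whether a methyl group alone on that chain carbon would give a number near that of compound 3 or one nearer those of compound 1 and compound 2. They also leave open how an amine, a carboxylic acid, a longer chain or a cyclopropane ring at the same carbon would read on this measure, and whether the step seen here would hold on another core.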